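This account rests on a few compounds, and the source may have more. Where it says the series, first, only, none or still open, it means among the compounds named here.

Compound 3 `CC1(C)Cc2c(-c3ccncc3)c(-c3ccccc3C#N)nn2C1` is the compound from which the step sets out. In a functional assay on MCF7 cells (Homo sapiens) for cytotoxicity, with a stated time of 72 h (on this read-out higher numbers stand for weaker inhibition and lower numbers for stronger inhibition), compound 3 does not reach a measurable number but only a limit of the assay, > 100000 nM. Compound 1 `CC1c2c(-c3ccncc3)c(-c3ccccc3C#N)nn2CC1(C)C` is its closest measured neighbour. In this assay compound 1 likewise stops at a limit, > 100000 nM. Compound 2 `Cc1cccc(-c2nn3c(c2-c2ccncc2)C(CO)C(C)(C)C3)n1` is the third measured compound. In this assay compound 2 again gives only a limit, > 100000 nM. Going by the values given here, the single step between measured compounds, a step that the two limits leave unreadable from compound 1 to compound 3, cannot be sized because both of its ends sit at the limit of > 100000 nM in this assay, at which 3 of the 3 values shown sit.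

Compound 4 `CC1(C)Cc2c(-c3ccncc3)c(-c3ccccn3)nn2C1` differs from compound 3 in one place: pyridin-2-yl in place of 2-cyanophenyl on an aromatic carbon. No measured step involves this exchange, and the one step that exists is of unreadable size, so nothing shown points toward stronger or weaker inhibition. The step that the limit leaves unreadable from compound 3 to compound 4 is therefore expected to be none beyond the scatter. Compound 4 is estimated at 150000 nM in this assay, within a range from 50000 nM to 500000 nM, most probably reported once more as a limit rather than a number.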

Compound 4, half-maximal inhibitory concentration: > 100000 nM
Compound 4: a limit, no number; the forecaster's own chance of this, stated with the estimate: 85%; the middle value does not contradict the limit.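

No step can be read from compound 3 to compound 4, because both stop at a limit of the assay and give no number: the limit of > 100000 nM in this assay, at which 4 of the 4 values shown sit. The compounds shown leave open which change to the shared core, if any, would give a measurable value in this assay.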